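A few compounds are considered here, and "the series" means these few. Any claim that something is new, unique, unknown or untested is made for them only; others in the source may bear on it.

Compound 1 `COc1cc(-c2cccc3nc(-c4cccc(F)c4)oc23)cc(OC)c1OC`: 2600 nM
Compound 2 `COc1cc(-c2nc3cccc(-c4cc(OC)c(OC)c(OC)c4)c3o2)ccc1O`: 15700 nM
Compound 3 `COc1cc(-c2cccc3nc(-c4ccc5cc[nH]c5c4)oc23)cc(OC)c1OC`: not yet measured

In a functional assay on A549 cells (Homo sapiens) for antiproliferative activity, read by MTT assay, with a stated time of 48 h (on this read-out higher numbers stand for weaker inhibition and lower numbers for stronger inhibition), compound 2 gives 15700 nM, the higher of the two numbers. Compound 3 differs from it as follows: 1H-indol-6-yl in place of 4-hydroxy-3-methoxyphenyl on an aromatic carbon. The change sits on an aromatic carbon of the five-membered aromatic ring with 1 nitrogen and 1 oxygen. Among the compounds with values here, the only measured step at this place is a 6.0-fold higher number from compound 1 to compound 2 (0.78 log units; beyond the scatter). Neither measured group is 1H-indol-6-yl, so that step gives only a rough size. A modest move to a lower number is expected, and the estimate is a 3.1-fold lower number from compound 2 to compound 3 (0.50 log units; beyond the scatter). For compound 3 the expected value is 5000 nM, with an estimated range of 1200 nM to 16000 nM.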

Compound 3, half-maximal inhibitory concentration: 55 nM
For compound 3 the middle estimate is 91-fold (1.96 log units) above the measured one, and the stated range ends above it.
By their numbers in this assay, from the lowest: compound 3; then compound 1; then compound 2.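

In this assay, the aromatic carbon of the five-membered aromatic ring with 1 nitrogen and 1 oxygen proves far more sensitive than the earlier step suggested: 1H-indol-6-yl gives a 290-fold lower number from compound 2 to compound 3 (2.46 log units; beyond the scatter) and a 47-fold lower number from compound 1 to compound 3 (1.67 log units; beyond the scatter), both large steps. Its heavy-atom and donor counts match those of 4-hydroxy-3-methoxyphenyl, so those counts do not separate the two groups. Nothing available bears on the reason for this gain.

Open: whether a naphthyl or benzofuranyl group at this carbon would match 1H-indol-6-yl, which would test the need for the indole nitrogen and its hydrogen.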